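Swapping a Hydroxymethyl for an Isopropyl on an Amide Chain

The source may report more compounds than this note shows. Statements on the series, on what has been measured and on what is new or still open speak of the compounds shown alone.

Of the compounds shown here, three have been tested in a functional assay on the whole organism (Tail, strain ICR) with Mus musculus as the target, in the tail flick test, with a stated time of 150 min, at a dose of 25 umol/kg by the oral route; a higher number here means a stronger effect of the compound at the dose given, a lower number a weaker effect. Compound 1, `O=C(O)[C@@H]1CCCN1C(=O)CN(c1nc(Cl)nc2[nH]cnc12)C1CC1`, gives 7.29%. Compound 2, `CC[C@H](C)[C@H](NC(=O)CN(c1nc(Cl)nc2[nH]cnc12)C1CC1)C(=O)O`, gives 6.71%. Compound 3, `O=C(CN(c1ncnc2c1ncn2C1CCCCO1)C1CC1)N[C@@H](CO)C(=O)OCc1ccccc1`, gives 18.3%. Of these three numbers, compound 3 stands highest: its nearest neighbour is compound 1, whose number lies below it by more than the usual scatter, and the furthest is compound 2, also below it by more than the scatter. Among the compounds with values here, no pair among the three differs in a single place, so no measured step is available to guide the next move.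

Compound 4, `CC(C)[C@H](NC(=O)CN(c1ncnc2c1ncn2C1CCCCO1)C1CC1)C(=O)OCc1ccccc1`, has not yet been measured in this assay . It differs from compound 3 in one place: isopropyl in place of hydroxymethyl on a saturated chain carbon bound to an amide-type nitrogen and a carbonyl carbon. The group that leaves carries one hydrogen-bond donor and one acceptor, the group that enters carries none, while the rest of the molecule is kept unchanged.

Within the data shown here, with no measured step of this kind among the three compounds, the expectation for compound 4 is a step from compound 3 to compound 4 of a number 2.3 percentage points lower from compound 3 to compound 4 (within the scatter), no larger than the scatter, in either direction. Compound 4 is therefore expected to give about 16%, within a range from 5% to 30%.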

Compound 4, a percentage reported as activity, at one dose (the size of the read-out at that dose, not a potency): 21.1%
For compound 4 the middle estimate is 5.1 percentage points below the measured one; measured number inside the range.
By their numbers in this assay, from the lowest: compounds 2 and 1 (each within the scatter of the next); then compounds 3 and 4 (each within the scatter of the next).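

In this assay the position on a saturated chain carbon bound to an amide-type nitrogen and a carbonyl carbon now has its first measured step, which is a number 2.8 percentage points higher from compound 3 to compound 4 (within the scatter). Hydroxymethyl carries a hydrogen-bond donor and a hydrogen-bond acceptor and isopropyl carries neither, yet in this one pair, removing them and adding a slightly larger carbon-only group leaves the read-out within the scatter, so this change neither clearly helps nor clearly harms at this dose and time. No measurement shown here explains why the two compounds read alike, so the result describes what happened without giving a reason for it.

Going by these compounds, whether this position accepts other kinds of group remains open: an amine, a carboxylic acid or a longer chain at the same place would show whether the read-out stays level or moves beyond the scatter. On these data alone, with a single pair tested at one dose and one time, it also remains open whether compound 3 and compound 4 would still read alike at other doses or times.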